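The compounds below may be only part of what the source reports. "The series", "measured", "known", "first", "only" and "open" are said of these compounds alone.

Of the compounds shown here, three have been measured in a functional assay on BJAB cells (Homo sapiens) for antiproliferative activity, with a stated time of 4 days; a higher number here means that more compound is needed for the effect, a lower number that less compound is needed. Compound 1 `CCSc1sc(-n2nc(C)c(Cc3ccccc3[N+](=O)[O-])c2C(=O)O)nc1-c1ccc(Cl)c(Cl)c1` gives 59000 nM, compound 2 `Cc1c(-c2cc(Cl)cc(Cl)c2)c(C(=O)O)nn1-c1nc(-c2cc(Cl)ccc2F)c(SC(C)C)s1` gives 4800 nM, and compound 3 `COc1cncc(-c2c(C)nn(-c3nc(-c4ccc(Cl)c(Cl)c4)c(SC(C)C)s3)c2C(=O)O)c1` gives 21000 nM. Compound 3 therefore stands second highest of the three numbers: compound 1 lies higher and compound 2 lower, both gaps beyond the scatter. Compound 4 `Cc1nn(-c2nc(-c3ccc(Cl)c(Cl)c3)c(SC(C)C)s2)c(C(=O)O)c1-c1ccccc1[N+](=O)[O-]` has not yet been measured in this assay; it differs from compound 3 in one place, (2-nitrophenyl in place of 5-methoxypyridin-3-yl on an aromatic carbon). Among the compounds with values here, no measured step matches this change, so the expectation rests on the spread of the three values alone. The step from compound 3 to compound 4 is expected to be modest and toward a higher number, about a 1.7-fold higher number from compound 3 to compound 4 (0.22 log units; within the scatter). Compound 4 is estimated at 35000 nM, within a range of 12000 nM to 100000 nM.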

Compound 4, half-maximal effective concentration: 4700 nM
Estimate against measurement, compound 4: 7.4-fold (0.87 log units) above; the whole stated range lies above it.
By their numbers in this assay, from the lowest: compounds 4 and 2 (each within the scatter of the next); then compound 3; then compound 1.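

Within the data shown here, replacing 5-methoxypyridin-3-yl with 2-nitrophenyl gives a 4.5-fold lower number from compound 3 to compound 4 (0.65 log units; beyond the scatter) in this assay and is the first readable step at this aromatic carbon. The position, next to the ring atom that bears a carboxy group and the ring atom that bears a methyl group, therefore does not tolerate all aryl groups equally in this read-out. No available evidence accounts for the step.

On these data alone, whether the step follows the nitro group or the carbon-only ring remains open. Phenyl or 2-aminophenyl at this carbon would separate the two.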